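This account rests on a few compounds, and the source may have more. Where it says the series, first, only, none or still open, it means among the compounds named here.

Measured compounds:
- compound 1, `N=C(N)N/N=C/c1c(-c2cccs2)nc2n1CCS2`: 17400 nM
- compound 2, `N=C(N)N/N=C/c1c(-c2cccs2)nc2sccn12`: 9770 nM
- compound 3, `N=C(N)N/N=C/c1c(-c2ccsc2)nc2sccn12`: 14100 nM

All three were tested in a functional assay on cells (Cancer cell lines, Homo sapiens) for inhibition; a higher number here means a weaker inhibitor of growth, a lower number a stronger inhibitor of growth. Compound 1 sits at the upper end of these three numbers, but its gap to compound 3 and its gap to compound 2 are each within the usual scatter, so the three cannot be told apart on these numbers alone.

The compound not yet measured is compound 4, `N=C(N)N/N=C/c1c(-c2ccsc2)nc2n1CCS2`. It differs from compound 1 in one place: thiophen-3-yl in place of thiophen-2-yl on an aromatic carbon.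

Going by the values given here, one measured step bears directly on this change, because it makes the same swap on a different shared core: a 1.4-fold higher number from compound 2 to compound 3 (0.16 log units; within the scatter). That step did not move the number beyond the scatter. On that basis, no change beyond the scatter is expected in this assay when going from compound 1 to compound 4, with a slight lean toward a higher number.

Compound 4 is therefore expected to give about 21000 nM in this assay, with a range from 9000 nM to 48000 nM, a step of a 1.2-fold higher number from compound 1 to compound 4 (0.08 log units; within the scatter).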

Compound 4, concentration for 50% growth inhibition: 22900 nM
For compound 4 the middle estimate is 1.1-fold (0.04 log units) below the measured one; low and high end bracket the measured number.
By their numbers in this assay, from the lowest: compounds 2, 3, 1 and 4 (each within the scatter of the next, the first and the last beyond it).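

In this assay, putting thiophen-3-yl in place of thiophen-2-yl on a second core gives a 1.3-fold higher number from compound 1 to compound 4 (0.12 log units; within the scatter), so this change again stays within the scatter. Going by these compounds alone, until now the swap had been seen on only one core, and it now reads alike on both: the same change on two cores in this assay, a 1.4-fold higher number (0.16 log units; within the scatter) from compound 2 to compound 3 and a 1.3-fold higher number (0.12 log units; within the scatter) from compound 1 to compound 4, 1.1-fold (0.04 log units) apart, within the scatter of two such steps At this position, on these two cores, the two ways of attaching the thiophene ring therefore cannot be told apart in this assay.

The compounds shown carry only thiophene rings here, so they leave open whether a different group at this position, such as a phenyl ring, an amine or a carboxylic acid, would move the number beyond the scatter. They also leave open what a methyl group or a chlorine atom on the thiophene ring itself would do.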